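Piperazine aryl variation on the aminothiophene series

The compounds below may be only part of what the source reports. "The series", "measured", "known", "first", "only" and "open" are said of these compounds alone.

Measured so far:
compound 1 `CC(C)N1CCN(Cc2csc(N)c2C(=O)c2ccc(Cl)cc2)CC1`, -7.4% in a functional assay on CHO cells with adenosine receptor A1 (Homo sapiens) as the target, read by cAMP accumulation and immunoassay, with a stated time of 6 min, tested at 10 uM; a higher number here means a weaker effect of the compound at the concentration tested, a lower number a stronger effect
compound 2 `Nc1scc(CN2CCN(c3ccccc3C(F)(F)F)CC2)c1C(=O)c1ccc(Cl)cc1`, -60%
compound 3 `Nc1scc(CN2CCN(c3c(F)cc(F)cc3F)CC2)c1C(=O)c1ccc(Cl)cc1`, -78%

Compound 3 stands lowest of the three numbers in this assay, with compound 2 nearest and compound 1 furthest away. Both aryl groups on the amine nitrogen in the ring give numbers well below the isopropyl of compound 1: a number 52.6 percentage points lower from compound 1 to compound 2 (beyond the scatter) and a number 70.6 percentage points lower from compound 1 to compound 3 (beyond the scatter). Between the two aryls the step is smaller: a number 18 percentage points lower from compound 2 to compound 3 (beyond the scatter).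

Compound 4 `Nc1scc(CN2CCN(c3cccc(Cl)c3)CC2)c1C(=O)c1ccc(Cl)cc1` is not yet measured. Its change from compound 3: 3-chlorophenyl in place of 2,4,6-trifluorophenyl on an amine nitrogen in a ring.

The step from compound 2 to compound 3 is the one that bears directly, as it also swaps one aryl for another on the same ring nitrogen, and it was modest. The large steps from compound 1 rest on leaving isopropyl, which does not apply here. Compound 4 keeps an aryl, so a step of modest size toward higher numbers, or none beyond the scatter, is expected; the estimate is a number 16 percentage points higher from compound 3 to compound 4 (beyond the scatter). Compound 4 is estimated at -62%, within -85% to -35%.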

Compound 4, a percentage reported as activity, at one concentration (the size of the read-out at that concentration, not a potency): -77%
The estimate for compound 4 lay 15 percentage points above the measured number; measured number inside the range.
By their numbers in this assay, from the lowest: compounds 3 and 4 (each within the scatter of the next); then compound 2; then compound 1.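

In this assay the 3-chlorophenyl on the amine nitrogen in the ring holds the level of the 2,4,6-trifluorophenyl, with a number 1 percentage points higher from compound 3 to compound 4 (within the scatter) here, so these two aryl groups cannot be told apart at this position. The 2-(trifluoromethyl)phenyl of compound 2 now stands apart from both, with a number 17 percentage points lower from compound 2 to compound 4 (beyond the scatter) as a second modest step, while a number 69.6 percentage points lower from compound 1 to compound 4 (beyond the scatter) gives a third aryl group that lies far from the isopropyl of compound 1. Nothing on hand explains why these groups give these numbers.

From the compounds shown here alone, whether a pyridyl ring or a benzyl group on the same nitrogen would keep this level remains open. With one concentration only, these numbers show the size of the effect of compound 3 and compound 4 at that concentration and cannot show whether one would have a stronger or weaker effect than the other at a different concentration.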